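The compounds below may be only part of what the source reports. "The series", "measured", "known", "first", "only" and "open" are said of these compounds alone.

Compound 2 `COC(=O)c1c[nH]c2ccccc2c1=O` is the simplest of the three measured compounds. In an ADME assay on J774 cells (Mus musculus) for cytotoxicity (on this read-out lower numbers stand for an effect already at smaller amounts and higher numbers for an effect only at larger amounts of compound), compound 2 gives > 20000 nM, which is a limit of the assay rather than a number. Compound 1 `CCCCc1ccc2[nH]cc(C(=O)OC)c(=O)c2c1` carries the change (butyl in place of hydrogen on an aromatic carbon). In this assay compound 1 gives > 20000 nM, again only a limit. The step that the two limits leave unreadable from compound 2 to compound 1 is therefore not readable, since the limit of > 20000 nM in this assay, at which 3 of the 3 values shown sit, shows where both values sit. Compound 3 `O=c1cc[nH]c2cc(OCCOc3ccccc3)ccc12` rests on another core; how its core differs from that of compound 2 is not broken down here. In this assay compound 3 gives > 20000 nM, also a limit. Compound 4 `CCCCc1cc2c(=O)cc[nH]c2cc1OCCOc1ccccc1` is not yet measured; it differs from compound 3 by butyl in place of hydrogen on an aromatic carbon, the same kind of change as that from compound 2 to compound 1, though here the place is in addition ortho to a large group. The step from compound 3 to compound 4 is expected to be a step that the limit leaves unreadable from compound 3 to compound 4, set beside the earlier unreadable one, because the limit of > 20000 nM in this assay, at which 3 of the 3 values shown sit, holds all three measured values. For compound 4 the expected value in this assay is 30000 nM, estimated to lie between 12000 nM and 100000 nM.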

Compound 4, half-maximal effective concentration: > 20000 nM
Compound 4 gave a limit, no number; the forecaster's own chance of this, stated with the estimate: 80%; the middle value is on the limit's open side.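

In this assay compound 4 gives > 20000 nM as a limit. The step from compound 3 to compound 4 therefore cannot be read, because both values sit at the same limit: the limit of > 20000 nM in this assay, at which 4 of the 4 values shown sit. The compounds shown leave open whether butyl in place of hydrogen on an aromatic carbon changes this read-out at all, and where any of their half-maximal concentrations lies.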